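Moving the fluorine after carbamoyl shuts down inhibition

The source may report more compounds than this note shows. Statements on the series, on what has been measured and on what is new or still open speak of the compounds shown alone.

Compound 1 `O=C(Nc1ccccc1F)N1c2ccnn2CC1c1ccccc1` gives 5.4 nM in a functional assay on cells (Neutrophil, Homo sapiens) for inhibition, with a stated time of 10 min; on this read-out lower numbers stand for stronger inhibition and higher numbers for weaker inhibition. Compound 2 `CCOC(=O)c1cnn2c1N(C(=O)Nc1ccc(F)cc1)C(c1ccccc1)C2` gives 10.3 nM in this assay. Compound 3 `NC(=O)c1cnn2c1N(C(=O)Nc1ccccc1F)C(c1ccccc1)C2` reaches only a limit of this assay, > 1000 nM, and this is the limit of > 1000 nM in this assay, at which 1 of the 3 values shown sits. The step of an at least 180-fold higher number from compound 1 to compound 3 (2.26 log units; beyond the scatter) is the only measured one bearing on this series, and it is large. Compound 4 `NC(=O)c1cnn2c1N(C(=O)Nc1ccc(F)cc1)C(c1ccccc1)C2` differs from compound 3 by 4-fluorophenyl in place of 2-fluorophenyl on an amide-type nitrogen. For the measured compounds named here, no measured pair isolates this change alone; compounds 1 and 2 carry the two fluorophenyl groups but also differ elsewhere, and their values sit within the usual scatter of each other. The step that the limit leaves unreadable from compound 3 to compound 4 is therefore expected to be small, in no clear direction. Compound 4 is estimated at 3000 nM, with a range from 800 nM to 20000 nM.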

Compound 4, half-maximal inhibitory concentration: 11.4 nM
Compound 4: middle estimate off by 260-fold (2.42 log units), on the high side, and the stated range ends above it.
By their numbers in this assay, from the lowest: compounds 1, 2 and 4 (each within the scatter of the next, the first and the last beyond it). At a limit, above all of these: compound 3.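

On the carbamoyl compounds, 4-fluorophenyl in place of 2-fluorophenyl on the amide-type nitrogen in this assay gives an at least 87-fold lower number from compound 3 to compound 4 (1.94 log units; beyond the scatter) and so brings inhibition back. Compound 3 is read only as a limit, so this step is a minimum: the limit of > 1000 nM in this assay, at which 1 of the 4 values shown sits. With 4-fluorophenyl present, amino in place of ethoxy on the carbonyl carbon gives a 1.1-fold higher number from compound 2 to compound 4 (0.04 log units; within the scatter) and leaves inhibition in the same range. Still open, on these data alone, is whether a carboxylic acid or a nitrile could stand in place of the carbamoyl group, and whether a plain phenyl or a 4-chlorophenyl could replace 4-fluorophenyl.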